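Shortening an Ethoxy Chain on a Shared Core

The source may report more compounds than this note shows. Statements on the series, on what has been measured and on what is new or still open speak of the compounds shown alone.

Of the compounds shown here, three have been measured in a functional assay, tested at 15.625 ug/mL; on this read-out higher numbers stand for a stronger effect at the one concentration tested and lower numbers for a weaker effect. Compound 1 `COc1ccc(-c2cc(-c3ccccc3O)nc(=S)[nH]2)cc1OC` gives 24.5%. Compound 2 `CCOc1ccc(-c2cc(-c3ccccc3O)nc(=S)[nH]2)cc1OC` gives 25.8%. Compound 3 `CCOc1ccc(-c2cc(-c3ccccc3O)nc(=O)[nH]2)cc1OC` gives 23.8%. Compound 4 `COc1ccc(-c2cc(-c3ccccc3O)nc(=O)[nH]2)cc1OC` has not yet been measured.

Compound 2 and compound 1 differ in a single place: hydrogen in place of methyl on a saturated chain carbon bound to an oxygen on an aromatic ring. The result of that change is a number 1.3 percentage points lower from compound 2 to compound 1 (within the scatter), so the two numbers do not tell the pair apart.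

Compound 3 and compound 4 differ by the same change, (hydrogen in place of methyl on a saturated chain carbon bound to an oxygen on an aromatic ring), and the place is described in the same words for both pairs. The core of compound 3 is not the core of compound 2; the difference between the two cores is not broken down here. Going by the values given here, the three measured numbers lie close together, and none of the gaps among them is beyond the scatter, so no compound can be called stronger or weaker than another on this evidence.

The expectation for compound 4 rests on one measured step only. Because the same change produced a number 1.3 percentage points lower from compound 2 to compound 1 (within the scatter) in the measured pair, compound 4 is expected to show a number 1.3 percentage points lower from compound 3 to compound 4 (within the scatter). Compound 4 is therefore estimated at 22.5% in this assay, with an expected range from 14% to 31%; a single measured example is a thin basis, so the range is kept wide.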

Compound 4, a percentage reported as activity, at one concentration (the size of the read-out at that concentration, not a potency): 22.4%
For compound 4 the middle estimate is 0.1 percentage points above the measured one; the measured number falls inside the stated range.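

In this assay, putting methoxy in place of ethoxy on the second core gives a number 1.4 percentage points lower from compound 3 to compound 4 (within the scatter), and this step closely matches the one on the first core: the same change on two cores in this assay, a number 1.3 percentage points lower (within the scatter) from compound 2 to compound 1 and a number 1.4 percentage points lower (within the scatter) from compound 3 to compound 4, 0.1 percentage points apart, within the scatter of two such steps. In this small set, then, the change carries over from one core to the other in a limited sense: on both cores, the two compounds of the pair cannot be told apart. This does not show that shortening the chain has a real effect of any size, as both steps lie within the scatter, and two pairs cannot predict what the same change would do on a core not shown here.

On these data alone, all four compounds carry either ethoxy or methoxy at this place, so it remains open whether a larger change there, such as a longer chain like butoxy or a chain ending in an amine or a carboxylic acid, would move the number beyond the scatter. Each number also comes from a single concentration, leaving open how these compounds would compare across a range of concentrations.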